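The compounds below may be only part of what the source reports. "The series", "measured", "known", "first", "only" and "open" are said of these compounds alone.

Working notes on the series. Compound 1 `C=C/C=C\C(C)C(OC(N)=O)[C@@H](C)[C@H](O)[C@@H](C)C/C=C\C(C)[C@@H](O)[C@@H](C)/C=C\C(O)C[C@@H]1OC(=O)C(C)[C@@H](O)[C@H]1C` gives 7.8 nM in a functional assay on A549 cells (Homo sapiens) for inhibition; on this read-out higher numbers stand for weaker inhibition and lower numbers for stronger inhibition. Compound 2 `C=C/C=C\C(C)C(OC(N)=O)[C@@H](C)[C@H](O)[C@@H](C)C/C(C)=C\C(C)[C@@H](O)[C@@H](C)/C=C\C(O)C[C@@H]1OC(=O)C(C)=C[C@H]1C` gives 1.8 nM in this assay, the lowest of the two numbers; the gap to compound 1 lies beyond the scatter. Compound 3 `C=C/C=C\C(C)C(OC(N)=O)[C@@H](C)[C@H](O)[C@@H](C)C/C(C)=C\C(C)[C@@H](O)[C@@H](C)/C=C\CC[C@@H]1OC(=O)C=C[C@H]1C` has not been measured. It differs from compound 2 as follows: a group of 10 heavy atoms (8 carbon, 2 oxygen; one six-membered non-aromatic ring with 1 hetero atom) in place of a group of 12 heavy atoms (9 carbon, 3 oxygen; one six-membered non-aromatic ring with 1 hetero atom), on a double-bonded chain carbon bound to a double-bonded chain carbon. For the measured compounds named here, no measured pair shares this change, so the expectation rests on compound 2 alone. A modest rise in the number is expected, a 2.8-fold higher number from compound 2 to compound 3 (0.44 log units; beyond the scatter), not certain to exceed the scatter. Compound 3 is estimated at 5 nM, within a range from 1.5 nM to 20 nM in this assay.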

Compound 3, half-maximal inhibitory concentration: 11.4 nM
Compound 3: the middle estimate sits 2.3-fold (0.36 log units) below what was measured; the range from low to high includes it.
By their numbers in this assay, from the lowest: compound 2; then compounds 1 and 3 (each within the scatter of the next).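

This position is not indifferent to the group it carries: in this assay, the swap gives a 6.3-fold higher number from compound 2 to compound 3 (0.80 log units; beyond the scatter), so inhibition weakens beyond the scatter. The group that leaves has 1 hydrogen-bond donor and 3 hydrogen-bond acceptors, the one that enters 0 hydrogen-bond donors and 2 hydrogen-bond acceptors, and this single step cannot separate those differences from the change in heavy atoms. Nothing available explains the step. Going by these compounds, how an amine or a carboxylic acid on the ring of the group that enters would read remains open.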